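The compounds below may be only part of what the source reports. "The series", "measured", "known", "first", "only" and "open" are said of these compounds alone.

Measured in a functional assay on PC-12 cells (Rattus norvegicus) for cytotoxicity, read by MTT assay, with stated times of 2 h and 24 h, tested at 10 uM; a higher number here means a stronger effect of the compound at the concentration tested, a lower number a weaker effect:

- compound 1 `Oc1cc(C(F)(F)F)ccc1-c1nc(-c2ccccc2O)n(-c2ccc(Cl)cc2)n1`: 96.1%
- compound 2 `Oc1cc(C(F)(F)F)ccc1-c1nc(-c2ccccc2O)n(-c2ccc(OC(F)(F)F)cc2)n1`: 92.5%
- compound 3 `N#Cc1ccc(-n2nc(-c3ccc(C(F)(F)F)cc3O)nc2-c2ccccc2O)cc1`: 98.9%

Compound 3 holds the highest of the three numbers in this assay, but neither gap separates it from the others: a number 2.8 percentage points higher from compound 1 to compound 3 (within the scatter) and a number 6.4 percentage points higher from compound 2 to compound 3 (within the scatter). The three measured compounds are therefore indistinguishable on these numbers.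

The next compound, compound 4 `Oc1cc(C(F)(F)F)ccc1-c1nc(-c2ccccc2O)n(-c2cc(F)cc(F)c2)n1`, differs from compound 3 by one exchange: 3,5-difluorophenyl in place of 4-cyanophenyl on an aromatic nitrogen.

All three measured steps bear on this exchange, since each of them also swaps the group on the same aromatic nitrogen-linked phenyl and leaves the rest of the shared core untouched: a number 3.6 percentage points lower from compound 1 to compound 2 (within the scatter), a number 2.8 percentage points higher from compound 1 to compound 3 (within the scatter), a number 6.4 percentage points higher from compound 2 to compound 3 (within the scatter). None of these reached beyond the scatter, and the groups exchanged there already span a halogen, a trifluoromethoxy and a cyano substituent. The move to 3,5-difluorophenyl has no direct precedent among the measured compounds, but the pattern seen so far gives no reason to expect a step beyond the scatter in this assay in either direction.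

The expected step from compound 3 to compound 4 is accordingly small: a number 4.9 percentage points lower from compound 3 to compound 4 (within the scatter). Compound 4 is estimated to give 94% in this assay, with a range from 82% to 100%.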

Compound 4, a percentage reported as activity, at one concentration (the size of the read-out at that concentration, not a potency): 106%
For compound 4 the middle estimate is 12 percentage points below the measured one, outside the stated range (above it).
By their numbers in this assay, from the lowest: compounds 2, 1, 3 and 4 (each within the scatter of the next, the first and the last beyond it).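

In this assay, going by these compounds alone, the group on the aromatic nitrogen now gives a step beyond the scatter, which none of the earlier pairs gave: a number 13.5 percentage points higher from compound 2 to compound 4 (beyond the scatter) with 3,5-difluorophenyl in place of 4-(trifluoromethoxy)phenyl. The other two exchanges at this position stay inside the scatter, a number 7.1 percentage points higher from compound 3 to compound 4 (within the scatter) and a number 9.9 percentage points higher from compound 1 to compound 4 (within the scatter), so 3,5-difluorophenyl separates from 4-(trifluoromethoxy)phenyl only, and not from 4-cyanophenyl or 4-chlorophenyl, and this position is shown to matter through that single pair alone. Nothing shown here accounts for the one step beyond the scatter.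

Going by these compounds, all four compounds carry a substituted phenyl on that nitrogen, so it stays open whether a single fluoro group would read like the 3,5-difluorophenyl group, and how an amine or a carboxylic acid on that phenyl, or a cyclohexyl ring in its place, would read in this assay. On these data alone, the two hydroxyl groups and the trifluoromethyl group of the shared core are also constant across these compounds, so their part in the reading remains open.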